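A few compounds are considered here, and "the series" means these few. Any claim that something is new, unique, unknown or untested is made for them only; others in the source may bear on it.

Three compounds have been measured in a functional assay on the whole organism (Tail, strain ICR) with Mus musculus as the target, in the tail flick test, with a stated time of 150 min, at a dose of 25 umol/kg by the oral route; on this read-out lower numbers stand for a weaker effect and higher numbers for a stronger effect at the one dose given:

Compound 1 `C[C@@H](O)[C@H](NC(=O)CN(c1nc(Cl)nc2[nH]cnc12)C1CC1)C(=O)O` gives 24%
Compound 2 `CSCC[C@H](NC(=O)CN(c1ncnc2c1ncn2C1CCCCO1)C1CC1)C(=O)OCc1ccccc1` gives 17.5%
Compound 3 `C[C@H](NC(=O)CN(c1ncnc2c1ncn2C1CCCCO1)C1CC1)C(=O)OCc1ccccc1` gives 6.01%

Compound 1 stands highest of the three numbers; compound 2 lies within the scatter of it, compound 3 beyond it. Among the measured compounds shown here, the only step between neighbouring structures, a number 11.5 percentage points lower from compound 2 to compound 3 (beyond the scatter), concerns a different change on a different core, so it bears only loosely on the present step. Compound 4 `NC(=O)C[C@H](NC(=O)CN(c1nc(Cl)nc2[nH]cnc12)C1CC1)C(=O)O` differs from compound 1 by carbamoylmethyl in place of 1-hydroxyethyl on a saturated chain carbon bound to an amide-type nitrogen and a carbonyl carbon. For the measured compounds named here, no measured pair shows this change, so the expectation rests mainly on compound 1 with its 24%. The step is expected to be small, a number 4 percentage points lower from compound 1 to compound 4 (within the scatter), not beyond the scatter. Compound 4 is therefore estimated at 20%, with a range from 5% to 38%.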

Compound 4, a percentage reported as activity, at one dose (the size of the read-out at that dose, not a potency): 7.51%
For compound 4 the middle estimate is 12.5 percentage points above the measured one, and the stated range covers the measured number.
By their numbers in this assay, from the lowest: compounds 3, 4, 2 and 1 (each within the scatter of the next, the first and the last beyond it).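

In this assay, the saturated chain carbon bound to an amide-type nitrogen and a carbonyl carbon proves sensitive on the core of compound 1: carbamoylmethyl in place of 1-hydroxyethyl gives a number 16.5 percentage points lower from compound 1 to compound 4 (beyond the scatter). Both groups count one hydrogen-bond donor and one hydrogen-bond acceptor, so the step appears with these counts unchanged. Nothing measured here accounts for the step.

As far as these compounds go, whether an amine or a longer carbon chain at this place would stay close to compound 1 or fall towards compound 4 remains open. From the compounds shown here alone, whether the same change would give a similar step on the core of compound 2 also remains open.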